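Phenoxy to dimethylamino: expectation for compound 3

This account rests on a few compounds, and the source may have more. Where it says the series, first, only, none or still open, it means among the compounds named here.

Two compounds of the series carry numbers in a functional assay on OVCAR-8 cells (Homo sapiens) for cytotoxicity, read by sulforhodamine B assay, with a stated time of 48 h, tested at 1 uM; on this read-out higher numbers stand for a weaker effect at the one concentration tested and lower numbers for a stronger effect. Compound 1 `COc1cc(C)cc(-c2nn(CC#N)cc2-c2ccc(-c3cccc(C(C)=O)c3)nc2)c1` gives 14% in this assay. Compound 2 `Cc1cc(O)cc(-c2nn(CC#N)cc2-c2ccnc(-c3ccc(Oc4ccccc4)cc3)c2)c1` gives -30% in this assay, the lowest of the two numbers shown; its nearest neighbour is compound 1, whose number lies higher by more than the usual scatter, so compound 2 shows the stronger effect of the pair.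

Compound 3 `Cc1cc(O)cc(-c2nn(CC#N)cc2-c2ccnc(-c3ccc(N(C)C)cc3)c2)c1` has not been measured. It differs from compound 2 in one place: dimethylamino in place of phenoxy on an aromatic carbon. Within the data shown here, no measured pair carries this change, so the size of its step in this assay cannot be taken from measured compounds; the expectation rests only on the value of compound 2 and on the change itself. The step from compound 2 to compound 3 is expected to be small and toward higher numbers, at a number 15 percentage points higher from compound 2 to compound 3 (beyond the scatter), not clearly beyond the scatter. On that basis compound 3 is expected to give -15% in this assay, within a range from -50% to 20%.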

Compound 3, a percentage reported as activity, at one concentration (the size of the read-out at that concentration, not a potency): 27%
For compound 3 the middle estimate is 42 percentage points below the measured one; the measured number lies above the stated range.
By their numbers in this assay, from the lowest: compound 2; then compound 1; then compound 3.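

Notes on the phenoxy position. In this assay, among these compounds, replacing phenoxy with dimethylamino on an aromatic carbon, para to a large group, gives a number 57 percentage points higher from compound 2 to compound 3 (beyond the scatter), and this is the first single-place comparison available. The position is therefore not indifferent to the group it carries: with the rest of the structure unchanged, the effect at the one concentration tested is clearly weaker with dimethylamino. The group that leaves contains a six-membered aromatic ring of carbon only and the group that enters contains no ring, while the counts of hydrogen-bond donors and acceptors match and neither group carries a net charge, but no measured property of either group bears on the step, and no explanation can be given for it.

Still open, on these data alone, is whether the size of the step follows the loss of the aromatic ring or the arrival of the nitrogen. Anilino, which holds both a ring and a nitrogen, together with methoxy and morpholine at the same place, would help separate these two readings.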